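A few compounds are considered here, and "the series" means these few. Any claim that something is new, unique, unknown or untested is made for them only; others in the source may bear on it.

The account opens with two measured compounds. Compound 1 `COc1ccccc1C1=NN(C(=O)c2ccc([N+](=O)[O-])o2)C(c2ccc([N+](=O)[O-])cc2)C1` was tested in a functional assay on T47D cells (Homo sapiens) for antiproliferative activity, read by CCK-8 assay, with a stated time of 72 h (on this read-out lower numbers stand for stronger inhibition and higher numbers for weaker inhibition), and returned only a limit of the assay, > 50000 nM, so no number is known for it. Compound 2 `COc1ccc(C2CC(c3ccccc3)=NN2C(=O)c2nc3ccccc3s2)cc1` stands at the same place on the numbers shown: in this assay compound 2 likewise gives a limit, > 50000 nM. Among the compounds with values here, both known values therefore rest together at the limit of > 50000 nM in this assay, at which 2 of the 2 values shown sit, and no step between measured compounds can be computed from them.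

Compound 3 `COc1ccc(C2CC(c3ccccc3)=NN2C(=O)c2ccncc2)cc1` has not yet been measured. It differs from compound 2 in a single place: pyridin-4-yl in place of 1,3-benzothiazol-2-yl on a carbonyl carbon. Within the data shown here, with both known values resting at the limit, there is no measured step to lean on, and the replacement alone gives no ground to expect a large move in this assay in either direction. Compound 3 is therefore expected to remain at or near the limit, with an estimated value of 50000 nM, in a range from 20000 nM to 150000 nM. The step of a number no higher from compound 2 to compound 3 (the limit leaves the size open) is accordingly expected to be none beyond the scatter.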

Compound 3, half-maximal inhibitory concentration: > 50000 nM
Compound 3 was reported as a limit; the forecaster's own chance of this, stated with the estimate: 70%; the middle value sits exactly at the limit.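

In this assay compound 3 gives > 50000 nM, which is a limit and not a number. Within the data shown here, compound 2 also gives only a limit, so no step between compound 2 and compound 3 can be read. The compounds shown leave open how pyridin-4-yl and 1,3-benzothiazol-2-yl compare on that carbonyl carbon, since all the values sit together: the limit of > 50000 nM in this assay, at which 3 of the 3 values shown sit.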